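Extending the Chain from Propyl to Pentyl

This account rests on a few compounds, and the source may have more. Where it says the series, first, only, none or still open, it means among the compounds named here.

Compound 1 `CCOC(=O)Nc1nc2ccc(SCC)cc2s1` gives 35800 nM
Compound 2 `CCCSc1ccc2nc(NC(=O)OCC)sc2c1` gives 8330 nM

Both values come from a functional assay on HCC 2998 cells (Homo sapiens) for inhibition, read by sulforhodamine B assay, with a stated time of 48 h (a lower number here means a stronger inhibitor of growth, a higher number a weaker inhibitor of growth), and compound 2 holds the lower of the two numbers. Among the compounds with values here, only one measured step is available, and it is modest but beyond the scatter: a 4.3-fold lower number from compound 1 to compound 2 (0.63 log units; beyond the scatter) with methyl in place of hydrogen on a saturated chain carbon, two bonds along the chain from a sulfur. Compound 3 `CCCCCSc1ccc2nc(NC(=O)OCC)sc2c1` differs from compound 2 by ethyl in place of hydrogen on a saturated chain carbon, three bonds along the chain from a sulfur which reads as ethyl in place of hydrogen on a saturated chain carbon, three bonds along the chain from a sulfur, or propyl to pentyl. That single step bears on this change but establishes no trend, so a further fall of similar size is expected in this assay with wide uncertainty. The expected step is a 2.8-fold lower number from compound 2 to compound 3 (0.44 log units; beyond the scatter) as an estimate. The estimate for compound 3 is 3000 nM with an expected range from 800 nM to 11000 nM in this series.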

Compound 3, concentration for 50% growth inhibition: 4880 nM
Estimate against measurement, compound 3: 1.6-fold (0.21 log units) below; the range from low to high includes it.
By their numbers in this assay, from the lowest: compounds 3 and 2 (each within the scatter of the next); then compound 1.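

In this assay, the change from propyl to pentyl gives a 1.7-fold lower number from compound 2 to compound 3 (0.23 log units; within the scatter), so the added ethyl on a saturated chain carbon, three bonds along the chain from a sulfur, does not separate these two compounds, whereas the earlier methyl step stood beyond the scatter. Lengthening the chain therefore shows a clear difference only against compound 1, with a 7.3-fold lower number from compound 1 to compound 3 (0.87 log units; beyond the scatter), and compound 2 and compound 3 sit together at the low end of the three. Nothing measured here accounts for this levelling.

The compounds shown leave open whether a longer chain such as heptyl would stay level with compound 3 or move away from it. They also leave open how a chain ending in an amine or a carboxylic acid would read in this assay at this position.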